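The source may hold more compounds than are shown below. What is called first, only, known or untested is meant among the compounds shown, and "the series" means these compounds.

Compound 1, with structure `O=S(=O)(Nc1ccc(-c2nc3ccccc3o2)cc1)c1ccc(Cl)s1`, is the starting point. In an assay on isolated protein for inhibition of malate dehydrogenase, mitochondrial (Sus scrofa), with stated times of 45 min and 30 min (on this read-out higher numbers stand for weaker inhibition and lower numbers for stronger inhibition), compound 1 gives > 63000 nM, which is a limit of the assay and not a number. Compound 2, `O=S(=O)(Nc1ccc2oc(-c3ccccc3)nc2c1)c1cccc(F)c1`, gives > 63000 nM in this assay, again a limit. Compound 3, `O=S(=O)(Nc1ccc2oc(-c3ccccc3)nc2c1)c1cccc(O)c1`, gives > 63000 nM, also a limit. Among the compounds with values here, the only measured step, a step that the two limits leave unreadable from compound 2 to compound 3, is therefore unreadable, and compound 1 stands at the same limit as the other two (the limit of > 63000 nM in this assay, at which 3 of the 3 values shown sit). The change to compound 4, `O=S(=O)(Nc1ccc(-c2nc3ccccc3o2)cc1)c1ccc(O)cc1`, is 4-hydroxyphenyl in place of 5-chlorothiophen-2-yl on a sulfonyl sulfur. Within the data shown here, no measured step touches the sulfonyl side of the molecule, so there is no guide to its size. Compound 4 is expected to remain at the limit as well, an expected step that the limit leaves unreadable from compound 1 to compound 4, giving an estimate of 100000 nM with range 40000 nM to 300000 nM.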

Compound 4, half-maximal inhibitory concentration: > 63000 nM
Compound 4: no number, only a limit (the forecaster's own chance of this, stated with the estimate: 90%); the middle value lies beyond the limit too.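

Compound 1 and compound 4 both sit at a limit of the assay, so no step between them can be read: the limit of > 63000 nM in this assay, at which 4 of the 4 values shown sit.

The compounds shown leave open whether any change to this series gives a readable value in this assay.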